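Adding chloro to a compound sitting at the limit

A few compounds are considered here, and "the series" means these few. Any claim that something is new, unique, unknown or untested is made for them only; others in the source may bear on it.

Compound 1 `N#Cc1ccc(/C=C/S(=O)(=O)Cc2ccc(Nc3ncnc4ccccc34)cc2)cc1` gives > 100000 nM (a limit)
Compound 2 `O=S(=O)(/C=C/c1ccc(F)cc1F)Cc1ccc(Nc2ncnc3ccccc23)cc1` gives > 100000 nM (a limit)
Compound 3 `O=S(=O)(/C=C/c1ccc(F)cc1F)Cc1ccc(Nc2ncnc3ccc(Br)cc23)cc1` gives 100000 nM (a number)

In a functional assay on PC-3 cells (Homo sapiens) (on this read-out higher numbers stand for weaker inhibition of growth and lower numbers for stronger inhibition of growth), compound 2 stands at > 100000 nM (a limit, not a number). Compound 4 `O=S(=O)(/C=C/c1ccc(F)cc1F)Cc1ccc(Nc2ncnc3cc(Cl)ccc23)cc1` differs from compound 2 by one change, chloro in place of hydrogen on an aromatic carbon with chloro in place of hydrogen on an aromatic carbon. The nearest measured change, bromo in place of hydrogen on an aromatic carbon, gave a number no higher from compound 2 to compound 3 (the limit leaves the size open) and compound 3 remains at 100000 nM with growth barely inhibited. The other measured change gave a step that the two limits leave unreadable from compound 1 to compound 2 and touches a different group. A small move toward stronger inhibition, or none beyond the scatter, is therefore expected, an estimated at least 1.1-fold lower number from compound 2 to compound 4 (0.04 log units; that floor lies within the scatter) in size. For compound 4 the expected value is 90000 nM within an estimated range (30000 nM to 150000 nM) and only a limit may again be reported.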

Compound 4, concentration for 50% growth inhibition: > 100000 nM
Compound 4: only a limit was reported; the forecaster's own chance of this, stated with the estimate: 60%; middle value at least 1.1-fold (0.04 log units) from the limit.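

Compound 2 and compound 4 both give a limit rather than a number, so no step between them can be read: the limit of > 100000 nM in this assay, at which 3 of the 4 values shown sit.

The compounds shown leave open whether chloro in place of hydrogen changes growth inhibition at all, and by how much.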